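The compounds below may be only part of what the source reports. "The series", "measured", "known", "first", "only" and "open" are said of these compounds alone.

Compound 1 `O=C(Nc1cccc(Nc2ncc(F)c(Nc3ccc(F)cc3)n2)c1)c1cnccn1` and compound 2 `O=C(Nc1cc(Cl)cc(Cl)c1)c1cccc(Nc2ncc(F)c(Nc3ccc(F)cc3)n2)c1` share a core but carry different amide groups. Within the data shown here, in a functional assay on KBVIN cells (Homo sapiens) for antiproliferative activity, read by sulforhodamine B assay, with a stated time of 3 days (a higher number here means a weaker inhibitor of growth, a lower number a stronger inhibitor of growth), compound 1 gives 20100 nM and compound 2 gives 20700 nM, so compound 2 stands level with the only other measured compound. Compound 3 `O=C(NCCO)c1cccc(Nc2ncc(F)c(Nc3ccc(F)cc3)n2)c1` keeps the core of compound 2 and makes one change: 2-hydroxyethyl in place of 3,5-dichlorophenyl on an amide-type nitrogen. In words, 2-hydroxyethyl sits in place of 3,5-dichlorophenyl on an amide-type nitrogen. Among the measured compounds shown here, only one measured step bears on this: a 1.0-fold higher number from compound 1 to compound 2 (0.01 log units; within the scatter), where (3,5-dichlorophenyl)carbamoyl replaced ((pyrazin-2-yl)carbonyl)amino on an aromatic carbon. For the measured compounds named here, that exchange stayed within the scatter, but no measured compound carries an open chain there, so the support is thin. No change beyond the scatter is therefore expected in this assay. The estimated step is a 1.2-fold higher number from compound 2 to compound 3 (0.06 log units; within the scatter). For compound 3 the expected value is 24000 nM, with a range from 10000 nM to 55000 nM.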

Compound 3, concentration for 50% growth inhibition: 21400 nM
Estimate against measurement, compound 3: 1.1-fold (0.05 log units) above; measured number inside the range.
By their numbers in this assay, from the lowest: compounds 1, 2 and 3 (each within the scatter of the next).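

In this assay, the amide-type nitrogen takes either 3,5-dichlorophenyl or 2-hydroxyethyl without a readable difference (a 1.0-fold higher number from compound 2 to compound 3 (0.01 log units; within the scatter)), even though this exchange removes an aromatic ring and both chlorines and brings in an open chain with a hydrogen-bond donor. The same holds when the (2-hydroxyethyl)carbamoyl group of compound 3 is set against the ((pyrazin-2-yl)carbonyl)amino group of compound 1 (a 1.1-fold higher number from compound 1 to compound 3 (0.03 log units; within the scatter)), so an open chain now joins the two ring-bearing groups, and all three compounds stand level in this assay. Nothing available explains why such different groups give matching numbers.

Going by these compounds, it remains open whether an amine or a carboxylic acid at the end of the chain would separate from these three compounds. The same question stands for a longer chain on that nitrogen.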